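From 4-hydroxyphenyl to 5-chloro-2-hydroxyphenyl against SK-OV-3 cells

This account rests on a few compounds, and the source may have more. Where it says the series, first, only, none or still open, it means among the compounds named here.

Measured in a functional assay on SK-OV-3 cells (Homo sapiens) for antiproliferative activity, read by MTT assay, with a stated time of 24 h; a higher number here means a weaker inhibitor, a lower number a stronger inhibitor:
Compound 1 `COc1ccc(C(=O)/C=C/c2ccccc2)c2c1C=CC(C)(C)O2`: > 10000 nM (a limit)
Compound 2 `COc1ccc(C(=O)/C=C/c2ccc(O)cc2)c2c1C=CC(C)(C)O2`: > 10000 nM (a limit)

The result for compound 2 is > 10000 nM, a limit of the assay and not a number. Both measured compounds therefore sit at the limit of > 10000 nM in this assay, at which 2 of the 2 values shown sit.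

Compound 3 `COc1ccc(C(=O)/C=C/c2cc(Cl)ccc2O)c2c1C=CC(C)(C)O2` carries 5-chloro-2-hydroxyphenyl in place of 4-hydroxyphenyl on a double-bonded chain carbon bound to a double-bonded chain carbon. Among the measured compounds shown here, the one measured step that bears on this change is a step that the two limits leave unreadable from compound 1 to compound 2, with hydroxy in place of hydrogen on an aromatic carbon. For the measured compounds named here, that step offers no size to carry over, and no measured compound contains chlorine. Only a move toward a stronger inhibitor could be read in this assay, and the data support no firm expectation of one. Another limit is a likely outcome for compound 3. The step expected is a step that the limit leaves unreadable from compound 2 to compound 3. For compound 3 the estimated value is 12000 nM, with an expected range from 3000 nM to 40000 nM.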

Compound 3, half-maximal inhibitory concentration: 6270 nM
For compound 3 the middle estimate is 1.9-fold (0.28 log units) above the measured one, and the stated range covers the measured number.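

In this assay, compound 3 is the only compound shown that gives a number and not a limit, while the other two remain at the limit: the limit of > 10000 nM in this assay, at which 2 of the 3 values shown sit.

On a double-bonded chain carbon bound to a double-bonded chain carbon, 5-chloro-2-hydroxyphenyl in place of 4-hydroxyphenyl gives an at least 1.5-fold lower number from compound 2 to compound 3 (0.20 log units; that floor lies within the scatter), and the same group in place of phenyl gives an at least 1.5-fold lower number from compound 1 to compound 3 (0.20 log units; that floor lies within the scatter). Both steps are floors that stay within the scatter, so this position can now yield a measurable value, but the data do not establish a change beyond the scatter, and the step from phenyl to 4-hydroxyphenyl still cannot be read.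

The change brings in chlorine and a different hydroxyphenyl pattern together, and the compounds shown do not separate the two. On these data alone, whether chlorine alone, hydroxy alone, or a bromine atom or an amine in place of the chlorine would give a number in this assay remains open.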